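The source may hold more compounds than are shown below. What is called first, only, known or untested is meant among the compounds shown, and "the series" means these compounds.

Measured compounds in an in vitro assay on 293-EBNA cells for binding affinity to corticotropin-releasing factor receptor 1 (Homo sapiens); on this read-out lower numbers stand for stronger inhibition and higher numbers for weaker inhibition:
compound 1 `CCCCN(CC)c1nc(C)nc2c1nnn2-c1c(C)cc(C)cc1C`: 27.5 nM
compound 2 `CCCCN(CC)c1nc(C)nc2c1nnn2-c1c(C)cc(C)nc1C`: 65 nM
compound 3 `CCC(COC)Nc1nc(C)nc2c1nnn2-c1c(C)cc(C)cc1C`: 59.4 nM

Compound 3 has the second-highest of the three numbers. Its value and that of compound 2 lie within the scatter of one another, while compound 1 sits beyond the scatter with the lower, stronger number.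

Compound 4 `CCCCC(CC)Nc1nc(C)nc2c1nnn2-c1c(C)cc(C)cc1C` has not been measured. It differs from compound 3 by propyl in place of methoxy on a saturated chain carbon, two bonds along the chain from a nitrogen on an aromatic ring. Going by the values given here, no measured pair isolates exactly this change. Among the compounds with values here, the only step on record bears on it indirectly: a 2.2-fold higher number from compound 1 to compound 3 (0.33 log units; beyond the scatter) went along with a move from a side chain made only of carbon and hydrogen to one carrying the methoxy group, and the number rose modestly. Compound 4 returns to a chain of only carbon and hydrogen, with the amino attachment kept as in compound 3, so a small step back toward the number of compound 1 is expected, or none beyond the scatter. The estimate for compound 4 in this assay is 38 nM, within 15 nM to 95 nM, which means an expected step of a 1.6-fold lower number from compound 3 to compound 4 (0.19 log units; within the scatter).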

Compound 4, inhibition constant: 7.6 nM
Compound 4: the middle estimate sits 5.0-fold (0.70 log units) above what was measured; measured number below the stated range.
By their numbers in this assay, from the lowest: compound 4; then compound 1; then compounds 3 and 2 (each within the scatter of the next).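

In this assay, the change at this saturated chain carbon gives a 7.8-fold lower number from compound 3 to compound 4 (0.89 log units; beyond the scatter), so an all-carbon propyl here does far better than methoxy, by more than the earlier step between compound 1 and compound 3 could suggest. The (1-ethylpentyl)amino group also outdoes the butyl(ethyl)amino group, with a 3.6-fold lower number from compound 1 to compound 4 (0.56 log units; beyond the scatter), so the higher number of compound 3 cannot be blamed on the switch of amino group type alone, since compound 4 keeps that type of attachment and still lies lowest. No measurement shown here explains why this swap has such an effect.

Methoxy and propyl differ in both atoms and length, so it remains open which of these matters, and a hydroxyl or a butyl group at this carbon would help to separate them. On these data alone, it is also open whether the (1-ethylpentyl)amino group brings a similar gain on the core of compound 2.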